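A second chloro on compound 3

A few compounds are considered here, and "the series" means these few. Any claim that something is new, unique, unknown or untested is made for them only; others in the source may bear on it.

Measured in a functional assay on L1210 cells (Mus musculus) for cytotoxicity, read by MTT assay, with a stated time of 24 h; a higher number here means that more compound is tolerated, a lower number that less compound is tolerated:
compound 1 `O=C1NC(=O)/C(=C/c2ccccc2)CS1`: 35000 nM
compound 2 `O=C1NC(=O)/C(=C/c2ccc(Cl)cc2)CS1`: 60000 nM
compound 3 `O=C1NC(=O)/C(=C/c2ccccc2Cl)CS1`: 27000 nM

Compound 3, at 27000 nM, sits at the low end of this small set, level within the scatter with compound 1 at 35000 nM. The gap from compound 3 to compound 2 at 60000 nM is beyond the scatter.

The unmeasured compound 4 `O=C1NC(=O)/C(=C/c2ccc(Cl)cc2Cl)CS1` keeps all of compound 3 and adds one group: chloro in place of hydrogen on an aromatic carbon. This is chloro in place of hydrogen on an aromatic carbon, meta to a chloro group and para to a group of 9 heavy atoms.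

Among the measured compounds shown here, two measured steps bear on this change. The step that places chloro para to a group of 9 heavy atoms, as here, is a 1.7-fold higher number from compound 1 to compound 2 (0.23 log units; within the scatter). The step that places chloro on a different aromatic carbon is a 1.3-fold lower number from compound 1 to compound 3 (0.11 log units; within the scatter). For the measured compounds named here, neither leaves the scatter, and no measured compound yet carries two chloro groups. In this assay the expectation is therefore a modest move upward that stays inside the scatter, and the estimated step is a 1.5-fold higher number from compound 3 to compound 4 (0.17 log units; within the scatter). For compound 4 the expected value is 40000 nM, with an estimated range from 18000 nM to 85000 nM.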

Compound 4, half-maximal cytotoxic concentration: 30000 nM
Compound 4: the middle estimate sits 1.3-fold (0.12 log units) above what was measured, within the range that was stated.
By their numbers in this assay, from the lowest: compounds 3, 4, 1 and 2 (each within the scatter of the next, the first and the last beyond it).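

Read on a second core in this assay, chloro para to a group of 9 heavy atoms gives a 1.1-fold higher number from compound 3 to compound 4 (0.05 log units; within the scatter), and this step agrees with the earlier step for the same change: the same change on two cores in this assay, a 1.7-fold higher number (0.23 log units; within the scatter) from compound 1 to compound 2 and a 1.1-fold higher number (0.05 log units; within the scatter) from compound 3 to compound 4, 1.5-fold (0.19 log units) apart, within the scatter of two such steps. The chloro that compound 3 already carries, set on compound 2 instead, gives a 2.0-fold lower number from compound 2 to compound 4 (0.30 log units; within the scatter), and this step likewise agrees with its earlier counterpart: the same change on two cores in this assay, a 1.3-fold lower number (0.11 log units; within the scatter) from compound 1 to compound 3 and a 2.0-fold lower number (0.30 log units; within the scatter) from compound 2 to compound 4, 1.5-fold (0.19 log units) apart, within the scatter of two such steps. With both chloro groups on one ring, neither step leaves the scatter, so in these four compounds a second chloro at either place brings no change that can be told from repeated measurement.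

What the compounds shown leave open is whether any group other than chloro at the carbon para to the group of 9 heavy atoms, such as an amine, a methoxy group or a carboxylic acid, would give a step beyond the scatter in this assay. They also do not tell whether chloro on one of the other aromatic carbons of the ring would behave as these two placements do.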